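Swapping a Nitrile for a Pentafluoroethyl Group

The source may hold more compounds than are shown below. What is called first, only, known or untested is meant among the compounds shown, and "the series" means these compounds.

Of the compounds shown here, two sharing one core have so far been measured in an assay on CHO cells, read by calcium flux; a higher number here means a weaker inhibitor, a lower number a stronger inhibitor. Compound 1 `CN(C)c1ccc(NC(=O)c2csc(Cc3c(Cl)cccc3Cl)n2)cc1` carries a dimethylamino group, and in this assay compound 1 gives 1270 nM. Compound 2 `N#Cc1ccc(NC(=O)c2csc(Cc3c(Cl)cccc3Cl)n2)cc1` carries a cyano group in its place, and in this assay compound 2 gives 720 nM. Within the data shown here, the only measured step is a 1.8-fold lower number from compound 1 to compound 2 (0.25 log units; within the scatter), and since it lies within the scatter, the two values cannot be told apart. Among the measured compounds shown here, of the two numbers, that of compound 2 is the lower, but its only neighbour, compound 1, sits within the scatter of it, so compound 2 is not singled out.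

Compound 3 `O=C(Nc1ccc(C(F)(F)C(F)(F)F)cc1)c1csc(Cc2c(Cl)cccc2Cl)n1` has not yet been measured. It differs from compound 2 in one place: 1,1,2,2,2-pentafluoroethyl in place of cyano on an aromatic carbon. For the measured compounds named here, no measured step covers this exchange; the one step known, cyano in place of dimethylamino on an aromatic carbon, was within the scatter and points in no direction. The expected step is a 1.0-fold lower number from compound 2 to compound 3 (0.01 log units; within the scatter), one that stays within the scatter. Compound 3 is therefore estimated at 700 nM, with a range from 250 nM to 2000 nM.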

Compound 3, half-maximal inhibitory concentration: 350 nM
For compound 3 the middle estimate is 2.0-fold (0.30 log units) above the measured one; measured number inside the range.
By their numbers in this assay, from the lowest: compound 3; then compounds 2 and 1 (each within the scatter of the next).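

In this assay, among these compounds, putting 1,1,2,2,2-pentafluoroethyl in place of cyano gives a 2.1-fold lower number from compound 2 to compound 3 (0.31 log units; beyond the scatter) and is the first single exchange here to clear the scatter, though only modestly. Set against the dimethylamino group, the same pentafluoroethyl group gives a 3.6-fold lower number from compound 1 to compound 3 (0.56 log units; beyond the scatter) in this assay and so shows that this aromatic carbon, para to a large group, can register a change in what it carries, which the step between compound 1 and compound 2 could not show. Nothing measured alongside these numbers speaks to the reason for either step.

The compounds shown leave open how the result depends on the chain itself, since neither the shorter trifluoromethyl group nor a longer chain such as heptafluoropropyl stands among them, and a carboxylic acid or a primary amine at this place would test a very different kind of group. They also leave open whether the gain from pentafluoroethyl would hold with a different group elsewhere on the shared core, given that every comparison so far rests on a single core and a single assay.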